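Methyl to Fluoro: A Small Step Expected

The source may report more compounds than this note shows. Statements on the series, on what has been measured and on what is new or still open speak of the compounds shown alone.

Compound 1 `COc1ccc(/C=C/C(=O)c2c(C)[n+]([O-])c3ccccc3[n+]2[O-])cc1`: 23000 nM
Compound 2 `Cc1ccc(/C=C/C(=O)c2c(C)[n+]([O-])c3ccccc3[n+]2[O-])cc1`: 14000 nM

Of the compounds shown here, two sharing one core have been measured in a functional assay on HSC-3 cells (Homo sapiens) for cytotoxicity, with a stated time of 48 h; on this read-out higher numbers stand for lower toxicity in this test and lower numbers for higher toxicity in this test. Compound 1 gives 23000 nM, and compound 2 gives 14000 nM. On the numbers shown, compound 2 stands at the lower figure, with compound 1 nearest to it, though the gap lies within the scatter, so neither can be called the more toxic. The change from compound 2 to compound 3 `Cc1c(C(=O)/C=C/c2ccc(F)cc2)[n+]([O-])c2ccccc2[n+]1[O-]` is fluoro in place of methyl on an aromatic carbon. Within the data shown here, only one measured step bears on it: a 1.6-fold lower number from compound 1 to compound 2 (0.22 log units; within the scatter), which exchanged one small group for another at the same place and stayed within the scatter. A change of this kind is therefore expected to give no step beyond the scatter in this assay in either direction. The estimated step is a 1.1-fold higher number from compound 2 to compound 3 (0.06 log units; within the scatter). Compound 3 is thus expected to give about 16000 nM, in the range 7000 nM to 40000 nM.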

Compound 3, half-maximal cytotoxic concentration: 7700 nM
For compound 3 the middle estimate is 2.1-fold (0.32 log units) above the measured one; the measured number falls inside the stated range.
By their numbers in this assay, from the lowest: compounds 3, 2 and 1 (each within the scatter of the next, the first and the last beyond it).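

In this assay, fluoro in place of methyl on this aromatic carbon, para to a large group, gives a 1.8-fold lower number from compound 2 to compound 3 (0.26 log units; within the scatter) and so does not separate 4-fluorophenyl from 4-methylphenyl. Fluoro in place of methoxy at the same place gives a 3.0-fold lower number from compound 1 to compound 3 (0.48 log units; beyond the scatter) and is the first step here to pass beyond the scatter, a modest one, which shows that this position is not wholly indifferent to the group it carries, although compound 2 lies within the scatter of both compound 1 and compound 3. Nothing at hand bears on what lies behind this step.

The compounds shown leave open whether an amine, a hydroxyl group or a chlorine atom at this place would stay within the same narrow span. They also leave open whether the step from methoxy to fluoro would hold on other cell lines.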